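A few compounds are considered here, and "the series" means these few. Any claim that something is new, unique, unknown or untested is made for them only; others in the source may bear on it.

Compound 1 `COc1ccc(C(=O)/C=C/c2ccc(N(C)C)cc2)c2c1C=CC(C)(C)O2`: 570 nM
Compound 2 `COc1ccc(C(=O)/C=C/c2ccc(Cl)cc2)c2c1C=CC(C)(C)O2`: > 10000 nM
Compound 3 `COc1ccc(C(=O)/C=C/c2ccc(O)cc2)c2c1C=CC(C)(C)O2`: > 10000 nM

These values come from a functional assay on SW-620 cells (Homo sapiens) for antiproliferative activity, read by MTT assay, with a stated time of 24 h; a lower number here means a stronger inhibitor, a higher number a weaker inhibitor. Compound 3 gives > 10000 nM, which is a limit of the assay and not a number. Compound 2 also stands at a limit, > 10000 nM.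

Compound 4 `COc1ccc(C(=O)/C=C/c2cccc(O)c2)c2c1C=CC(C)(C)O2` has 3-hydroxyphenyl in place of 4-hydroxyphenyl on a double-bonded chain carbon bound to a double-bonded chain carbon. The nearest evidence is two large steps beyond the scatter, with chloro or hydroxy in place of dimethylamino: an at least 17-fold higher number from compound 1 to compound 2 (1.24 log units; beyond the scatter) and an at least 17-fold higher number from compound 1 to compound 3 (1.24 log units; beyond the scatter). Compound 4 also lacks dimethylamino, so no gain is expected. The expected result is a number no higher from compound 3 to compound 4 (the limit leaves the size open), with no change beyond the scatter. Compound 4 is estimated at 10000 nM, with an expected range of 3000 nM to 30000 nM.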

Compound 4, half-maximal inhibitory concentration: > 10000 nM
Compound 4: only a limit was reported (the forecaster's own chance of this, stated with the estimate: 75%); the middle value lies on the limit itself.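

Moving the hydroxy group, with 3-hydroxyphenyl in place of 4-hydroxyphenyl, does not lift activity into the readable range of this assay: compound 4 gives > 10000 nM, a limit of the assay and not a number. Neither hydroxyphenyl group makes up for the loss of the 4-(dimethylamino)phenyl group, the change being an at least 17-fold higher number from compound 1 to compound 4 (1.24 log units; beyond the scatter). The steps from compound 2 and from compound 3 to compound 4 cannot be read: the limit of > 10000 nM in this assay, at which 3 of the 4 values shown sit.

As far as these compounds go, it stays open how far these compounds lie past the limit. From the compounds shown here alone, it also stays open whether another amine, such as diethylamino or a plain amino group, would match compound 1.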